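Carbamoyl Replaces Aminomethyl on the Pyrrolidine of Compound 3

The compounds below may be only part of what the source reports. "The series", "measured", "known", "first", "only" and "open" are said of these compounds alone.

Three analogues sharing one core have been measured in an assay on isolated protein for inhibition of DNA topoisomerase 1 (Homo sapiens), with a stated time of 15 min; a higher number here means a weaker inhibitor, a lower number a stronger inhibitor. Compound 1, `CN[C@@H]1CCN(c2c(F)cc3c(=O)c(C(=O)O)cn(Cc4ccc(-c5ccccc5)cc4)c3c2OC)C1`, gives 57700 nM. Compound 2, `COc1c(N2CC[C@@H](N)C2)c(F)cc2c(=O)c(C(=O)O)cn(Cc3ccc(-c4ccccc4)cc3)c12`, gives 92200 nM. Compound 3, `CNC[C@@H]1CCN(c2c(F)cc3c(=O)c(C(=O)O)cn(Cc4ccc(-c5ccccc5)cc4)c3c2OC)C1`, gives 155000 nM and stands highest of the three; its nearest neighbour is compound 2, its furthest compound 1. The step of a 2.7-fold higher number from compound 1 to compound 3 (0.43 log units; beyond the scatter) is modest, whereas a 1.7-fold higher number from compound 2 to compound 3 (0.23 log units; within the scatter) and a 1.6-fold higher number from compound 1 to compound 2 (0.20 log units; within the scatter) stay within the scatter.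

The compound still to be measured is compound 4, `COc1c(N2CC[C@@H](C(N)=O)C2)c(F)cc2c(=O)c(C(=O)O)cn(Cc3ccc(-c4ccccc4)cc3)c12`. It differs from compound 3 by carbamoyl in place of (methylamino)methyl on a saturated ring carbon. Among the measured compounds shown here, none of the measured steps exchanges a nitrogen-bearing chain for a carbonyl-bearing one, so no step bears directly on this change; the two steps that alter the same ring carbon, a 2.7-fold higher number from compound 1 to compound 3 (0.43 log units; beyond the scatter) and a 1.7-fold higher number from compound 2 to compound 3 (0.23 log units; within the scatter), show that this position has so far moved the numbers little. The author therefore expects a small step, if any, beyond the scatter, and leans towards a somewhat higher number, with the estimate a 1.3-fold higher number from compound 3 to compound 4 (0.11 log units; within the scatter) for compound 4. Compound 4 is estimated at 200000 nM in this assay, with a range from 60000 nM to 600000 nM.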

Compound 4, half-maximal inhibitory concentration: > 200000 nM
Compound 4: no number, only a limit; the forecaster's own chance of this, stated with the estimate: 25%; the middle value sits exactly at the limit.
By their numbers in this assay, from the lowest: compounds 1, 2 and 3 (each within the scatter of the next, the first and the last beyond it). At a limit, above all of these: compound 4.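

Compound 4 gives no number in this assay, only a limit of the assay: the limit of > 200000 nM in this assay, at which 1 of the 4 values shown sits. With carbamoyl on this saturated ring carbon, the floors of the steps are an at least 2.1-fold higher number from compound 2 to compound 4 (0.33 log units; beyond the scatter) and an at least 3.4-fold higher number from compound 1 to compound 4 (0.53 log units; beyond the scatter), both beyond the scatter, whereas an at least 1.2-fold higher number from compound 3 to compound 4 (0.11 log units; that floor lies within the scatter) has a floor within it, so compound 4 is not shown to part from compound 3. The earlier compounds shown here all carry an amine at this place and show only how amine-bearing groups compare, while compound 4 adds that carbamoyl, which has no amine nitrogen, brings no stronger inhibition than amino or methylamino.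

The compounds shown leave open how far beyond its limit compound 4 lies, and with it the full size of all three steps. They also leave open how a carboxylic acid, a hydroxymethyl group or a longer amine chain on this ring carbon would read in this assay, and whether an amine of any kind is needed there to reach the lower numbers.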